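Swapping a Sulfone Arm for a Plain Hexyl Chain

This account rests on a few compounds, and the source may have more. Where it says the series, first, only, none or still open, it means among the compounds named here.

Of the compounds shown here, three sharing one core have been tested in an ADME assay on L1210/0 cells (Mus musculus) for cytotoxicity, with a stated time of 48 h; on this read-out higher numbers stand for weaker inhibition and lower numbers for stronger inhibition. Compound 1 `O=c1[nH]c(=O)n([C@H]2C[C@H](O)[C@@H](CO)O2)cc1/C=C/I` gives 63900 nM. For compound 2 `O=c1[nH]c(=O)n([C@H]2C[C@H](O)[C@@H](CO)O2)cc1C#CCCCO` the read-out is only a limit, > 200000 nM. For compound 3 `CS(=O)(=O)Cc1cn([C@H]2C[C@H](O)[C@@H](CO)O2)c(=O)[nH]c1=O` the read-out is likewise a limit, > 200000 nM. Compound 3 therefore stands at the weak end of what is shown, together with compound 2, because of the limit of > 200000 nM in this assay, at which 2 of the 3 values shown sit; the step of an at least 3.1-fold higher number from compound 1 to compound 3 (0.49 log units; beyond the scatter) places it well behind compound 1, while the step that the two limits leave unreadable from compound 2 to compound 3 cannot be sized.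

Compound 4 `CCCCCCc1cn([C@H]2C[C@H](O)[C@@H](CO)O2)c(=O)[nH]c1=O` is not yet measured. It differs from compound 3 by pentyl in place of methylsulfonyl on a saturated chain carbon bound to an aromatic carbon. For the measured compounds named here, none of the measured steps exchanges one saturated chain for another, so only the standing of compound 3 itself guides the expectation. Compound 4 is expected to stay near that limit, with an estimated step of an at least 1.3-fold lower number from compound 3 to compound 4 (0.12 log units; that floor lies within the scatter) in this assay. Compound 4 is thus estimated at 150000 nM, between 40000 nM and 400000 nM, before its measurement is known.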

Compound 4, half-maximal inhibitory concentration: > 200000 nM
Compound 4 was reported as a limit (the forecaster's own chance of this, stated with the estimate: 55%); middle value at least 1.3-fold (0.12 log units) away from the limit.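

In this assay the value of compound 4 is again only a limit: the limit of > 200000 nM in this assay, at which 3 of the 4 values shown sit. Taking away the two hydrogen-bond acceptors of methylsulfonyl and putting a plain pentyl in its place therefore does not bring this position off that limit, so a saturated chain without acceptors reads no differently here from the sulfone arm. Replacing 2-iodoethenyl with hexyl gives an at least 3.1-fold higher number from compound 1 to compound 4 (0.49 log units; beyond the scatter), which leaves 2-iodoethenyl as the only group shown with a true number, while the steps among the three compounds at the limit cannot be read.

On these data alone, whether those three compounds differ from one another at all remains open. Also open, as far as these compounds go, is how a bromine atom, an amine or a carboxylic acid on this aromatic carbon would read against 2-iodoethenyl.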